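Thiourea variant of a weakly antiproliferative thiophene series

The source may hold more compounds than are shown below. What is called first, only, known or untested is meant among the compounds shown, and "the series" means these compounds.

compound 1 `N#Cc1ccccc1CN1CCc2c(sc(NC(=O)c3ccccc3Cl)c2C(N)=O)C1`: > 50000 nM
compound 2 `NC(=O)c1c(NC(=O)c2ccccc2Cl)sc2c1CCN(Cc1ccc(Cl)cc1)C2`: > 50000 nM
compound 3 `NC(=O)c1c(NC(=O)c2ccccc2Cl)sc2c1CCN(C(=S)Nc1ccccc1Br)C2`: 24600 nM

In a functional assay on HeLa cells (Homo sapiens) for antiproliferative activity, with a stated time of 24 h (on this read-out lower numbers stand for stronger inhibition and higher numbers for weaker inhibition), compound 1 gives only a limit, > 50000 nM. Compound 2 likewise gives only a limit, > 50000 nM. Among the compounds with values here, compound 3 is the one compound with a number, 24600 nM, and it stands apart from the other two, which sit at the limit of > 50000 nM in this assay, at which 2 of the 3 values shown sit.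

The step from compound 1 to compound 3 reads an at least 2.0-fold lower number from compound 1 to compound 3 (0.30 log units; that floor lies within the scatter), and the step from compound 2 to compound 3 reads an at least 2.0-fold lower number from compound 2 to compound 3 (0.30 log units; that floor lies within the scatter). The step from compound 1 to compound 2 is a step that the two limits leave unreadable from compound 1 to compound 2.

Compound 4 `COc1ccc(NC(=S)N2CCc3c(sc(NC(=O)c4ccccc4Cl)c3C(N)=O)C2)cc1` differs from compound 3 by 4-methoxyphenyl in place of 2-bromophenyl on an amide-type nitrogen. Within the data shown here, none of the measured steps exchanges a substituent on the thiourea aryl group; all three replace the whole group on the ring amine, so they bear on this change only indirectly, and both readable steps reach just the floor of the scatter. The expected step from compound 3 to compound 4 is therefore a 1.0-fold higher number from compound 3 to compound 4 (0.01 log units; within the scatter), no change beyond the scatter. Compound 4 is estimated at 25000 nM, with a range of 8000 nM to 50000 nM.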

Compound 4, half-maximal inhibitory concentration: 36400 nM
Compound 4: middle estimate off by 1.5-fold (0.16 log units), on the low side; the measured number falls inside the stated range.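

In this assay, within the data shown here, the first direct exchange on the thiourea aryl group reads a 1.5-fold higher number from compound 3 to compound 4 (0.17 log units; within the scatter), so 4-methoxyphenyl and 2-bromophenyl on this amide-type nitrogen are not told apart, even though the entering group adds a hydrogen-bond acceptor. Both thioureas now give numbers, and the comparisons with the other two compounds read an at least 1.3-fold lower number from compound 2 to compound 4 (0.13 log units; that floor lies within the scatter) and an at least 1.3-fold lower number from compound 1 to compound 4 (0.13 log units; that floor lies within the scatter), so the gain from the thiourea stays a floor within the scatter. Compound 1 and compound 2 remain limits and not numbers: the limit of > 50000 nM in this assay, at which 2 of the 4 values shown sit.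

A thiourea carrying a plain phenyl, a carboxylic acid on the aryl ring or a longer alkyl chain in place of the aryl group would test whether this nitrogen substituent matters at all. Going by these compounds, whether the thiocarbonyl itself counts stays open, and a urea carbonyl in its place would address that.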